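This account rests on a few compounds, and the source may have more. Where it says the series, first, only, none or still open, it means among the compounds named here.

Working notes on the series.

Compound 1 `Clc1ccccc1CSc1nnc(-c2cnccn2)o1` and compound 2 `Brc1ccccc1CSc1nnc(-c2cnccn2)o1` share one core; compound 3 `Clc1cccc(CSc2nnc(-c3cnccn3)n2-c2ccccc2)c1` and compound 4 `Brc1cccc(CSc2nnc(-c3cnccn3)n2-c2ccccc2)c1` share another. How the two cores differ is not broken down here. In a functional assay on BGC-823 cells (Homo sapiens) for antiproliferative activity, read by MTT assay, with a stated time of 48 h (on this read-out higher numbers stand for weaker inhibition and lower numbers for stronger inhibition), compound 1 gives 27700 nM, and compound 2 gives 17600 nM. The change from compound 1 to compound 2 is bromo in place of chloro on an aromatic carbon, and the step is a 1.6-fold lower number from compound 1 to compound 2 (0.20 log units; within the scatter). In this assay compound 3 gives 20300 nM, which sits between the other two measured values and within the scatter of both.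

Compound 4 is not yet measured. It differs from compound 3 by bromo in place of chloro on an aromatic carbon. This is the same kind of change as from compound 1 to compound 2, though the surroundings differ: in the first pair the halogen sits ortho to a large group, in the second pair meta to a large group. The halogen exchange has been seen once within the series and gave a step that stayed within the scatter.

On that basis, the step from compound 3 to compound 4 is expected to be small, about a 1.4-fold lower number from compound 3 to compound 4 (0.13 log units; within the scatter), because the earlier exchange from compound 1 to compound 2 gave a 1.6-fold lower number from compound 1 to compound 2 (0.20 log units; within the scatter). The estimate for compound 4 in this assay is 15000 nM, with the expected range running from 7000 nM to 32000 nM. Within the data shown here, the range is wide since only one earlier instance of this exchange is available, and on a different core.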

Compound 4, half-maximal inhibitory concentration: 18300 nM
Compound 4: the middle estimate sits 1.2-fold (0.09 log units) below what was measured; low and high end bracket the measured number.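

In this assay, bromo in place of chloro on the second core gives a 1.1-fold lower number from compound 3 to compound 4 (0.05 log units; within the scatter), and set beside the same exchange on the first core, the two steps cannot be told apart: the same change on two cores in this assay, a 1.6-fold lower number (0.20 log units; within the scatter) from compound 1 to compound 2 and a 1.1-fold lower number (0.05 log units; within the scatter) from compound 3 to compound 4, 1.4-fold (0.15 log units) apart, within the scatter of two such steps In this small set, then, the exchange carries from one core to the other without any step that stands out from the scatter, which fits a change that matters little on either core. Among these compounds, this does not show that bromo and chloro are truly equivalent or that the exchange has a real effect in either direction, and with only two pairs, which also differ in where the halogen sits, it does not establish a general rule for other cores.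

The compounds shown leave open whether a group other than a halogen on the aromatic ring, such as an amine or a carboxylic acid, would move the number beyond the scatter. Among the compounds shown here, they also leave open what a longer chain in place of the benzyl group would do on either core, since every change read so far is the one exchange of chloro for bromo.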